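Urea aryl swap on the pyrazole series: compound 4

A few compounds are considered here, and "the series" means these few. Any claim that something is new, unique, unknown or untested is made for them only; others in the source may bear on it.

Compound 1 `COc1cc(Cl)cc(-c2nn(-c3cccc(NC(=O)Nc4cccc(C(F)(F)F)c4)c3)cc2-c2ccncc2)c1` is the reference of this set. In a functional assay on SF-268 cells (Homo sapiens) for inhibition, read by sulforhodamine B assay, with a stated time of 48 h, tested at 1 uM (on this read-out lower numbers stand for a stronger effect and higher numbers for a weaker effect at the one concentration tested), compound 1 gives 79%, the lowest of the three numbers shown. Compound 2 `COc1cc(Cl)cc(-c2nn(-c3cccc(NC(=O)c4cccc(C(F)(F)F)c4)c3)cc2-c2ccncc2)c1` gives 100% in this assay, and the step of a number 21 percentage points higher from compound 1 to compound 2 (beyond the scatter) is the only one that can be isolated here. Within the data shown here, compound 3 `O=C(Nc1cccc(-n2cc(-c3ccncc3)c(-c3cc(O)cc(Cl)c3)n2)c1)Nc1ccc(Cl)c(Cl)c1` gives 89% in this assay, a value that lies within the scatter of the value of compound 1; compound 3 carries the 3,4-dichlorophenyl urea together with a hydroxyl in place of the methoxy group of compound 1, so no single-point step links it to compound 1.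

Compound 4 `COc1cc(Cl)cc(-c2nn(-c3cccc(NC(=O)Nc4ccc(Cl)c(Cl)c4)c3)cc2-c2ccncc2)c1` differs from compound 1 as follows: 3,4-dichlorophenyl in place of 3-(trifluoromethyl)phenyl on an amide-type nitrogen. Among the measured compounds shown here, no measured step bears directly on this change. The step from compound 1 to compound 2 concerns the urea linkage itself, not the aryl group, and is of no direct use. What the values of compound 1 and compound 3 show is that the 3,4-dichlorophenyl urea, on a closely related core, sits within the scatter of compound 1.

The step of a number 5 percentage points higher from compound 1 to compound 4 (within the scatter) is therefore expected to stay within the scatter. Compound 4 is estimated at 84% in this assay, with a range from 68% to 100%.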

Compound 4, a percentage reported as activity, at one concentration (the size of the read-out at that concentration, not a potency): 88%
Compound 4: the middle estimate sits 4 percentage points below what was measured, within the range that was stated.
By their numbers in this assay, from the lowest: compounds 1, 4 and 3 (each within the scatter of the next); then compound 2.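

In this assay, among these compounds, the step of a number 9 percentage points higher from compound 1 to compound 4 (within the scatter) is the first direct reading of an aryl swap on this amide-type nitrogen, and it does not separate 3,4-dichlorophenyl from 3-(trifluoromethyl)phenyl. Among the compounds shown here, the step of a number 1 percentage points lower from compound 3 to compound 4 (within the scatter) gives the first matched reading of methyl in place of hydrogen on the oxygen on the aromatic ring, and this change is also not separated from the parent. The step of a number 12 percentage points lower from compound 2 to compound 4 (beyond the scatter) shows a stronger effect for compound 4, but the amino link and the aryl group change together, so this step alone cannot assign the difference to either one.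

No available measurement gives a reason for these readings. Going by these compounds, whether an aminophenyl, a carboxyphenyl or a cyclohexyl group on this nitrogen would move the value beyond the scatter of compound 1 remains open.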